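This account rests on a few compounds, and the source may have more. Where it says the series, first, only, none or still open, it means among the compounds named here.

Working notes on the series. All three measured compounds share one core; compound 1 `O=[N+]([O-])c1ccc(-c2nc3cc(C(F)(F)F)ccc3[nH]2)cc1` carries nitro, compound 2 `CCN(CC)CC(=O)Nc1ccc(-c2nc3cc(C(F)(F)F)ccc3[nH]2)cc1` the (((diethylamino)methyl)carbonyl)amino group and compound 3 `O=C(CCl)Nc1ccc(-c2nc3cc(C(F)(F)F)ccc3[nH]2)cc1` the ((chloromethyl)carbonyl)amino group. In an ADME assay on Vero cells (Chlorocebus sabaeus) for cytotoxicity (a lower number here means that less compound is tolerated, a higher number that more compound is tolerated), compound 1 gives 45000 nM, compound 2 gives 24000 nM and compound 3 gives 35000 nM; compound 3 thus stands second highest of the three numbers, though every pairwise step among them lies within the scatter. Compound 4 `O=C(CN1CCCC1)Nc1ccc(-c2nc3cc(C(F)(F)F)ccc3[nH]2)cc1` differs from compound 3 by pyrrolidin-1-yl in place of chloro on a saturated chain carbon bound to a carbonyl carbon. Among the measured compounds shown here, the one measured step at the same place, a 1.5-fold higher number from compound 2 to compound 3 (0.16 log units; within the scatter), stayed within the scatter, so no step beyond the scatter is expected here either. For compound 4 a value of 28000 nM is expected, in the range 14000 nM to 56000 nM, an expected step of a 1.3-fold lower number from compound 3 to compound 4 (0.10 log units; within the scatter).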

Compound 4, half-maximal cytotoxic concentration: > 100000 nM
Compound 4 gave a limit, no number; the forecaster's own chance of this, stated with the estimate: 5%; middle value at least 3.5-fold (0.55 log units) away from the limit.
By their numbers in this assay, from the lowest: compounds 2, 3 and 1 (each within the scatter of the next). At a limit, above all of these: compound 4.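

In this assay compound 4 gives a limit and not a number: the limit of > 100000 nM in this assay, at which 1 of the 4 values shown sits. Among the compounds shown here, at this saturated chain carbon bound to a carbonyl carbon, pyrrolidin-1-yl in place of chloro gives an at least 2.8-fold higher number from compound 3 to compound 4 (0.45 log units; beyond the scatter) and pyrrolidin-1-yl in place of diethylamino gives an at least 4.1-fold higher number from compound 2 to compound 4 (0.61 log units; beyond the scatter), the first steps here beyond the scatter, so the amine present at this place matters. Against the nitro compound the result is an at least 2.2-fold higher number from compound 1 to compound 4 (0.34 log units; beyond the scatter), whereas neither earlier replacement of nitro left the scatter.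

Still open, on these data alone, is whether morpholin-4-yl, piperidin-1-yl or a longer chain carrying pyrrolidin-1-yl would also reach this limit. As far as these compounds go, the actual number for compound 4 also remains open.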